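A Group Swap Repeated Across Two Cores

A few compounds are considered here, and "the series" means these few. Any claim that something is new, unique, unknown or untested is made for them only; others in the source may bear on it.

Compound 1 `CC(O)(CSc1cccc(S(F)(F)(F)(F)F)c1)C(=O)Nc1ccc(S(F)(F)(F)(F)F)cc1`: 25000 nM
Compound 2 `CC(O)(CSc1cccc(C(F)(F)F)c1)C(=O)Nc1ccc(S(F)(F)(F)(F)F)cc1`: 18300 nM
Compound 3 `CC(O)(COc1ccc(S(F)(F)(F)(F)F)cc1)C(=O)Nc1ccc(S(F)(F)(F)(F)F)cc1`: 9800 nM

Of the compounds shown here, three have been measured in a functional assay on LNCaP cells (Homo sapiens) for antiproliferative activity, read by propidium iodide staining, with a stated time of 96 h; a lower number here means a stronger inhibitor, a higher number a weaker inhibitor. In this assay compound 1 gives 25000 nM, compound 2 gives 18300 nM and compound 3 gives 9800 nM. Compound 2 differs from compound 1 by a group of 4 heavy atoms (1 carbon, 3 fluorine; no ring) in place of a group of 6 heavy atoms (5 fluorine, 1 sulfur; no ring), on an aromatic carbon, which gave a 1.4-fold lower number from compound 1 to compound 2 (0.14 log units; within the scatter). Compound 2 and compound 3 lie within the scatter of each other, while the gap from compound 1 to compound 3 lies beyond it. The difference between the core of compound 1 and the core of compound 3 is not broken down here. Compound 4 `CC(O)(COc1ccc(S(F)(F)(F)(F)F)cc1)C(=O)Nc1ccc(C(F)(F)F)cc1` is not yet measured; it differs from compound 3 by a group of 4 heavy atoms (1 carbon, 3 fluorine; no ring) in place of a group of 6 heavy atoms (5 fluorine, 1 sulfur; no ring), on an aromatic carbon, sitting para to a large group where the earlier change sat meta to a large group, so it is the same kind of change rather than the same change. Because the earlier step was a 1.4-fold lower number from compound 1 to compound 2 (0.14 log units; within the scatter), a similarly small step is expected, and the estimated step is a 1.3-fold lower number from compound 3 to compound 4 (0.12 log units; within the scatter). Compound 4 is therefore expected to give about 7500 nM, with a likely range from 3500 nM to 16000 nM.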

Compound 4, half-maximal inhibitory concentration: 11700 nM
For compound 4 the middle estimate is 1.6-fold (0.19 log units) below the measured one; low and high end bracket the measured number.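

In this assay, trifluoromethyl in place of the group of 6 heavy atoms gave a 1.2-fold higher number from compound 3 to compound 4 (0.08 log units; within the scatter), so the step on this core stayed as small as the one on the first core. The two steps do not differ beyond what repeated measurement allows, and the change carried from one core to the other with little effect on the number: the same change on two cores in this assay, a 1.4-fold lower number (0.14 log units; within the scatter) from compound 1 to compound 2 and a 1.2-fold higher number (0.08 log units; within the scatter) from compound 3 to compound 4, 1.6-fold (0.21 log units) apart, within the scatter of two such steps This does not fix a direction for the change, and two cores say nothing about a third.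

Open, as far as these compounds go, is whether a nitrile, a methoxy group or an amine in that place would move the number beyond the scatter. Also open, from the compounds shown here alone, is whether swapping the other such group of compound 3 gives a step of like size.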